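Methylation of a terminal amine in a tetralin sulfone series

This account rests on a few compounds, and the source may have more. Where it says the series, first, only, none or still open, it means among the compounds named here.

Measured compounds:
compound 1, `CNCC1CCCc2cc(S(=O)(=O)c3ccccc3)ccc21`, 0.316 nM
compound 2, `CN(C)CC1CCCc2cc(S(=O)(=O)c3ccccc3)ccc21`, 0.0631 nM
compound 3, `NCC(=O)NC[C@@H]1CCCc2cc(S(=O)(=O)c3cccc(F)c3)ccc21`, 0.316 nM

In an assay on isolated protein for displacement of a labelled ligand from 5-hydroxytryptamine receptor 6 (Homo sapiens) (a higher number here means a weaker inhibitor, a lower number a stronger inhibitor), compound 1 and compound 3 stand level at the digits given, and compound 2 gives the lowest number of the three. From compound 1 to compound 2 the change is methyl in place of hydrogen on an amine nitrogen, and this step reads a 5.0-fold lower number from compound 1 to compound 2 (0.70 log units; beyond the scatter). Compound 4, `CNCC(=O)NC[C@@H]1CCCc2cc(S(=O)(=O)c3cccc(F)c3)ccc21`, has not yet been measured; it differs from compound 3 by methyl in place of hydrogen on an amine nitrogen. The difference between the core of compound 1 and the core of compound 3 is not broken down here. The two changes are the same kind of change, not the same: in compound 1 the amine nitrogen has two other neighbours, saturated chain carbon and saturated chain carbon, whereas in compound 3 it has one, saturated chain carbon. On that footing a smaller step is expected, a 2.0-fold lower number from compound 3 to compound 4 (0.30 log units; within the scatter), because compound 3 starts from 0.316 nM and the earlier step was a 5.0-fold lower number from compound 1 to compound 2 (0.70 log units; beyond the scatter). Compound 4 is therefore estimated at 0.16 nM in this assay, between 0.05 nM and 0.5 nM.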

Compound 4, inhibition constant: 0.159 nM
Beside the measured number, compound 4's estimate is 1.0-fold (0.00 log units) above it; low and high end bracket the measured number.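

In this assay, methyl in place of hydrogen on the amine nitrogen of the second core gives a 2.0-fold lower number from compound 3 to compound 4 (0.30 log units; within the scatter). Set beside the step on the first core, the two readings cannot be told apart: the same change on two cores in this assay, a 5.0-fold lower number (0.70 log units; beyond the scatter) from compound 1 to compound 2 and a 2.0-fold lower number (0.30 log units; within the scatter) from compound 3 to compound 4, 2.5-fold (0.40 log units) apart, within the scatter of two such steps. This shows that the change gives no sign of behaving differently on the two cores, but the new step alone cannot be told from scatter, so it does not show a real gain on the core of compound 3, and two pairs make no rule for the series.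

The compounds shown leave open how a dimethylamino group would read on the core of compound 3. They also leave open whether an ethyl group on that nitrogen would follow methyl.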